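This account rests on a few compounds, and the source may have more. Where it says the series, first, only, none or still open, it means among the compounds named here.

Compound 2 `Cc1cc(=O)oc2cc(OCc3cn(CCO)nn3)ccc12` is one of two close analogues tested for how much of them cultured cells tolerate. In an ADME assay on Huh-7 cells (Homo sapiens) for cytotoxicity, read by MTT assay, with a stated time of 72 h (a higher number here means that more compound is tolerated, a lower number that less compound is tolerated), compound 2 gives > 100 ug/mL, which is a limit of the assay rather than a number. Its partner compound 1 `Cc1cc(F)ccc1-n1cc(COc2ccc3c(C)cc(=O)oc3c2)nn1` carries 4-fluoro-2-methylphenyl on the aromatic nitrogen where compound 2 carries 2-hydroxyethyl. In this assay compound 1 gives > 100 ug/mL, again a limit. The step that the two limits leave unreadable from compound 1 to compound 2 therefore cannot be read, because of the limit of > 100 ug/mL in this assay, at which 2 of the 2 values shown sit. Compound 3 `Cc1cc(=O)oc2cc(OCc3cn(Cc4ccc([N+](=O)[O-])cc4)nn3)ccc12` is not yet measured; it differs from compound 2 by 4-nitrophenyl in place of hydroxymethyl on a saturated chain carbon bound to an aromatic nitrogen. Among the compounds with values here, the one measured step on the same aromatic nitrogen has no readable size, so the step of a number no higher from compound 2 to compound 3 (the limit leaves the size open) expected here rests only on both neighbours sitting at the limit. Compound 3 is estimated at 100 ug/mL, with a range from 40 ug/mL to 200 ug/mL, and most likely it too reports only the limit.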

Compound 3, half-maximal cytotoxic concentration: > 100 ug/mL
Compound 3 ended at the assay's limit; the forecaster's own chance of this, stated with the estimate: 65%; the middle value lies on the limit itself.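

Compound 2 and compound 3 both report a limit rather than a number, so the step between them cannot be read: the limit of > 100 ug/mL in this assay, at which 3 of the 3 values shown sit. The compounds shown leave open how much of each is actually tolerated in this assay, and whether their differing groups change that amount at all.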